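A few compounds are considered here, and "the series" means these few. Any claim that something is new, unique, unknown or untested is made for them only; others in the source may bear on it.

Measured compounds: compound 1 `C/C(=N\O)c1ccc(NC(=O)CSc2nnc(-c3ccccc3)n2-c2ccccc2)cc1` gives 67%; compound 2 `CCn1c(SCC(=O)Nc2ccc(/C(C)=N/O)cc2)nnc1-c1ccc(OC)c(OC)c1` gives 75%; compound 3 `COc1ccc(-c2nnc(SCC(=O)Nc3ccc(/C(C)=N/O)cc3)n2-c2ccccc2)cc1` gives 69%, all in a functional assay on the whole organism (strain albino) for inhibition, with Rattus norvegicus as the target, read by paw edema, with stated times of 30 min and 4 h, at a dose of 0.28 mmol/kg by the oral route; on this read-out higher numbers stand for more inhibition at the one dose given (going by the name of the read-out) and lower numbers for less inhibition.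

Compound 3 differs from compound 1 by methoxy in place of hydrogen on an aromatic carbon, and the step of a number 2 percentage points higher from compound 1 to compound 3 (within the scatter). Compound 2 shares the amide and oxime part with compound 1, but the difference between the two cores is not broken down here. Compound 4 `CCn1c(SCC(=O)Nc2ccc(/C(C)=N/O)cc2)nnc1-c1cc(OC)c(OC)c(OC)c1` is not yet measured; it differs from compound 2 by methoxy in place of hydrogen on an aromatic carbon. This is the same kind of change as from compound 1 to compound 3, but not the same: there the entering group sits para to a large group, here it sits ortho to a methoxy group, meta to a large group and meta to a methoxy group. Since the earlier step of a number 2 percentage points higher from compound 1 to compound 3 (within the scatter) stayed within the scatter, the step from compound 2 to compound 4 is also expected to be small, a number 1 percentage points higher from compound 2 to compound 4 (within the scatter). Compound 4 is therefore estimated at 76%, between 63% and 88%.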

Compound 4, a percentage reported as inhibition, in the whole organism at one dose (the size of the read-out at that dose, not a potency): 70%
Beside the measured number, compound 4's estimate is 6 percentage points above it; the range from low to high includes it.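

Set on a second core, methoxy in place of hydrogen on an aromatic carbon gives a number 5 percentage points lower from compound 2 to compound 4 (within the scatter) in this assay. Beside the earlier step, the two steps show no difference that can be read: the same change on two cores in this assay, a number 2 percentage points higher (within the scatter) from compound 1 to compound 3 and a number 5 percentage points lower (within the scatter) from compound 2 to compound 4, 7 percentage points apart, within the scatter of two such steps. The change therefore carries across these two cores without a readable effect on either, but the entering methoxy sits in a different place in each pair, and two small steps do not show how it would behave on other cores or at other places.

The compounds shown leave open whether another group on this aromatic ring, such as an amine or a carboxylic acid, would give a step beyond the scatter. They also leave open what a longer chain in place of the ethyl group of compound 4 would do.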